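The source may hold more compounds than are shown below. What is called first, only, known or untested is meant among the compounds shown, and "the series" means these compounds.

Compound 1, `O=C(NCc1ccc(CNS(=O)(=O)c2ccccc2Cl)cc1)c1ccc(CNc2ncccn2)cc1`, sits at the highest of the two numbers shown in an assay on MDA-MB-231 cells for binding affinity to C-X-C chemokine receptor type 4 (Homo sapiens), read by microscopy, with stated times of 10 min and 30 min (on this read-out higher numbers stand for an effect only at larger amounts of compound and lower numbers for an effect already at smaller amounts), where compound 1 gives 1000 nM. Compound 2, `O=C(NCc1ccc(CNS(=O)(=O)c2ccccc2)cc1)c1ccc(CNc2ncccn2)cc1`, gives 1 nM in this assay, and the step of a 1000-fold lower number from compound 1 to compound 2 (3.00 log units; beyond the scatter) is a large one. Compound 3, `O=C(NCc1ccc(CNS(=O)(=O)c2ccc(F)cc2)cc1)c1ccc(CNc2ncccn2)cc1`, reaches only the limit of this assay, at > 1000 nM; this is the limit of > 1000 nM in this assay, at which 1 of the 3 values shown sits. Accordingly the step of a number no lower from compound 1 to compound 3 (the limit leaves the size open) cannot be sized, while the step of an at least 1000-fold higher number from compound 2 to compound 3 (3.00 log units; beyond the scatter) is large.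

Compound 4, `Cc1ccccc1S(=O)(=O)NCc1ccc(CNC(=O)c2ccc(CNc3ncccn3)cc2)cc1`, is compound 1 with methyl in place of chloro on an aromatic carbon. Among the compounds with values here, of the steps measured, only the one from compound 1 to compound 2 bears on this change, since it alters the same aromatic carbon. That step removed the chloro entirely, whereas here a methyl enters in its place, so the outcome for compound 4 is expected to lie somewhere between the two ends it frames. Compound 4 is therefore expected to give 300 nM in this assay, within a range from 30 nM to 3000 nM, an expected step of a 3.3-fold lower number from compound 1 to compound 4 (0.52 log units; beyond the scatter).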

Compound 4, effective concentration (reported as EC, without a stated level of effect): 10 nM
Beside the measured number, compound 4's estimate is 30-fold (1.48 log units) above it, outside the stated range (below it).
By their numbers in this assay, from the lowest: compound 2; then compound 4; then compound 1.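

In this assay, methyl in place of chloro gives a 100-fold lower number from compound 1 to compound 4 (2.00 log units; beyond the scatter), so the high number of compound 1 does not follow from just any group on this aromatic carbon, ortho to a large group, while a 10-fold higher number from compound 2 to compound 4 (1.00 log units; beyond the scatter) shows that methyl here still does not match hydrogen. The 2-methylphenyl group also sets itself apart from the 4-fluorophenyl group, with an at least 100-fold lower number from compound 3 to compound 4 (2.00 log units; beyond the scatter). Compound 3 stands at a limit of the assay, not at a number: the limit of > 1000 nM in this assay, at which 1 of the 4 values shown sits.

What the compounds shown leave open is where other groups on this carbon, such as methoxy, an amine or a longer chain, would fall among these values. They also leave open whether methyl on another carbon of this ring would behave as it does here.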